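The compounds below may be only part of what the source reports. "The series", "measured", "known", "first", "only" and "open" are said of these compounds alone.

Three compounds share one core and differ only in the group sitting on a saturated chain carbon bound to an aromatic carbon and a saturated chain carbon. In a physicochemical assay for solubility, measured as kinetic solubility, at pH 2 (on this read-out lower numbers stand for lower solubility and higher numbers for higher solubility), compound 1 `CC(C)C(c1nnc[nH]1)c1ccc(-c2ccc3cccc(F)c3c2)[nH]c1=O` gives 31800 nM, compound 2 `CC(C)C(Cc1ncc[nH]1)c1ccc(-c2ccc3cccc(F)c3c2)[nH]c1=O` gives 33800 nM, and compound 3 `CC(C)C(/C=C1\CCNC1=O)c1ccc(-c2ccc3cccc(F)c3c2)[nH]c1=O` gives 23600 nM. On these numbers compound 3 stands nearest to compound 1 and furthest from compound 2, yet both steps of a 1.3-fold lower number from compound 1 to compound 3 (0.13 log units; within the scatter) and a 1.4-fold lower number from compound 2 to compound 3 (0.16 log units; within the scatter) lie within the scatter, as does a 1.1-fold higher number from compound 1 to compound 2 (0.03 log units; within the scatter), so the three compounds cannot be told apart on this read-out.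

Compound 4 `CC(C)C(c1ccc(-c2ccc3cccc(F)c3c2)[nH]c1=O)N1CCN/C1=N\C#N` brings a new group to the same saturated chain carbon: a group of 8 heavy atoms (4 carbon, 4 nitrogen; one five-membered non-aromatic ring with 2 hetero atoms) in place of a group of 7 heavy atoms (5 carbon, 1 nitrogen, 1 oxygen; one five-membered non-aromatic ring with 1 hetero atom), on a saturated chain carbon bound to an aromatic carbon and a saturated chain carbon. Among the measured compounds shown here, no measured step touches the entering group itself. For the measured compounds named here, the steps that bear on the place, all within the scatter, show that swapping one group for another there has so far left solubility unmoved. The step of a 1.1-fold higher number from compound 3 to compound 4 (0.03 log units; within the scatter) is therefore expected to stay within the scatter. For compound 4 a value of 25000 nM is estimated, with a range from 12000 nM to 50000 nM.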

Compound 4, solubility: 32500 nM
For compound 4 the middle estimate is 1.3-fold (0.11 log units) below the measured one; the measured number falls inside the stated range.
By their numbers in this assay, from the lowest: compounds 3, 1, 4 and 2 (each within the scatter of the next).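

Among the compounds shown here, compound 4 carries a group unlike the earlier ones at this saturated chain carbon, with 4 nitrogen atoms and a triple bond, yet in this assay every comparison with the earlier compounds stays within the scatter: a 1.4-fold higher number from compound 3 to compound 4 (0.14 log units; within the scatter), a 1.0-fold lower number from compound 2 to compound 4 (0.02 log units; within the scatter) and a 1.0-fold higher number from compound 1 to compound 4 (0.01 log units; within the scatter). Four different groups at this place, aromatic and non-aromatic rings alike, now cannot be told apart on this read-out. Nothing available here explains this lack of separation.

The compounds shown leave open whether a carboxylic acid or an amine on this carbon would give a step beyond the scatter. They also leave open whether changes elsewhere on the shared core would do so.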